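Carbamoyl for fluoro on the hydroxyethyl series

This account rests on a few compounds, and the source may have more. Where it says the series, first, only, none or still open, it means among the compounds named here.

Compound 1 `C[C@H](Oc1cc2cc(F)ccc2nc1N)c1cc2c(cnn2CC(=O)O)cc1-n1cccn1` is measured in an ADME assay on cells (Hepatocyte, Homo sapiens) for metabolic stability (on this read-out lower numbers stand for slow clearance and higher numbers for fast clearance), at 21 uL/min. Compound 2 `C[C@H](Oc1cc2cc(C(N)=O)ccc2nc1N)c1cc2[nH]ncc2cc1-n1cccn1` in this assay gives only a limit, < 3 uL/min, the assay reporting no number for it; this is the limit of < 3 uL/min in this assay, at which 1 of the 3 values shown sits. Compound 3 `C[C@H](Oc1cc2cc(F)ccc2nc1N)c1cc2c(cnn2CCO)cc1-n1cccn1`, carrying the hydroxyethyl chain, has no number in this assay: its entry reads "not determined" (no result reported), so compound 3 stands nowhere on the scale shown, and no measured step between compounds that differ in one place exists in this set. Compound 4 `C[C@H](Oc1cc2cc(C(N)=O)ccc2nc1N)c1cc2c(cnn2CCO)cc1-n1cccn1` has not yet been measured in this assay. From compound 3 to compound 4 the change is carbamoyl in place of fluoro on an aromatic carbon; the carbamoyl now sits where the fluoro stood. Because compound 3 has no value, no size can be given for this step, and no direction beyond the scatter of this assay is claimed. Compound 4 is expected to sit at 6 uL/min, in the range 3 uL/min to 15 uL/min, with a real chance that only a limit is returned.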

Compound 4, intrinsic clearance in a liver preparation (reported as CLH), per the amount of preparation that the assay uses: 4 uL/min
For compound 4 the middle estimate is 1.5-fold (0.18 log units) above the measured one, within the range that was stated.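

In this assay compound 4 gives 4 uL/min, a number and not a limit, so a carbamoyl compound carrying 2-hydroxyethyl on the aromatic nitrogen can be placed on the scale. Compound 2 stands only at a limit of the assay: the limit of < 3 uL/min in this assay, at which 1 of the 4 values shown sits. Going by these compounds, with the carbamoyl held constant, 2-hydroxyethyl in place of hydrogen on an aromatic nitrogen gives an at least 1.3-fold higher number from compound 2 to compound 4 (0.12 log units; that floor lies within the scatter), so this step has only a floor and its true size stays unknown.

The step from fluoro to carbamoyl cannot be read, as compound 3 has no value. Also open, on these data alone, is how an amine in place of the carbamoyl on this aromatic carbon, or a longer chain on the aromatic nitrogen, would read in this assay.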